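Neopentyl in place of phenyl and measured cytotoxicity

The source may hold more compounds than are shown below. What is called first, only, known or untested is meant among the compounds shown, and "the series" means these compounds.

Compound 1 `NC(=O)COc1ccc2c(c1)S(=O)(=O)C=C(c1c(O)c3cc(F)ccc3n(Cc3ccc(F)cc3)c1=O)N2`, compound 2 `CS(=O)(=O)Nc1ccc2c(c1)S(=O)(=O)C=C(c1c(O)c3ccc(F)cc3n(Cc3ccc(F)cc3)c1=O)N2` and compound 3 `CS(=O)(=O)Nc1ccc2c(c1)S(=O)(=O)C=C(c1c(O)c3cc(F)ccc3n(Cc3ccccc3)c1=O)N2` share one core and were examined in an ADME assay on 2209-23 cells (Homo sapiens) for cytotoxicity, read by WST assay; on this read-out higher numbers stand for lower toxicity in this test and lower numbers for higher toxicity in this test. In this assay compound 1 gives > 50000 nM, which is a limit of the assay and not a number. Compound 2 in this assay likewise returns only a limit, > 50000 nM. Compound 3 in this assay also stops at a limit, > 50000 nM. Among the compounds with values here, compound 3 therefore stands where the other two stand, namely at the limit of > 50000 nM in this assay, at which 3 of the 3 values shown sit, and no step between measured compounds can be sized from these results. Compound 4 `CC(C)(C)CCn1c(=O)c(C2=CS(=O)(=O)c3cc(NS(C)(=O)=O)ccc3N2)c(O)c2cc(F)ccc21` has not yet been measured and differs from compound 3 in one place: neopentyl in place of phenyl on a saturated chain carbon bound to an aromatic nitrogen. Because compound 3 sits at the limit of > 50000 nM in this assay, at which 3 of the 3 values shown sit, no step beyond the scatter is expected in this assay, a number no higher from compound 3 to compound 4 (the limit leaves the size open). Compound 4 is accordingly expected to give about 50000 nM in this assay, within a range from 20000 nM to 100000 nM, and most likely to be reported once more only as a limit.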

Compound 4, half-maximal cytotoxic concentration: > 50000 nM
Compound 4 ended at the assay's limit; the forecaster's own chance of this, stated with the estimate: 85%; the middle value lies on the limit itself.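

No step can be read between compound 3 and compound 4 in this assay, because each value is only a limit: the limit of > 50000 nM in this assay, at which 4 of the 4 values shown sit.

The compounds shown leave open how far any of them lies past that limit, and whether neopentyl in place of phenyl changes the read-out at all.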